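The source may report more compounds than this note shows. Statements on the series, on what has been measured and on what is new or still open speak of the compounds shown alone.

Measured so far in a functional assay on MT2 cells (Homo sapiens) for cytotoxicity; a higher number here means that more compound is tolerated, a lower number that less compound is tolerated:
- compound 1 `CC(C)=CCOc1cccc(Nc2nccs2)c1`: 23000 nM
- compound 2 `CC(C)=CCOc1cc(Nc2nccs2)ccc1C#N`: 500 nM

Not yet measured: compound 3 `COc1ccc(Nc2nccs2)cc1OCC=C(C)C`.

Compound 2, at 500 nM, holds the lower of the two numbers, so less of it is tolerated than of compound 1. Compound 3 is reached from compound 2 by methoxy in place of cyano on an aromatic carbon, ortho to a (3-methylbut-2-en-1-yl)oxy group and para to a (1,3-thiazol-2-yl)amino group. Going by the values given here, one measured step bears on this: a 46-fold lower number from compound 1 to compound 2 (1.66 log units; beyond the scatter), a large step beyond the scatter, with cyano in place of hydrogen on that same carbon. Among the compounds with values here, no methoxy compound has been measured, so the effect of the entering group remains open. With cyano gone, much of that large step is expected to be given back, which points to a higher number in this assay, though probably not all the way to compound 1 at 23000 nM. The expected change is a 16-fold higher number from compound 2 to compound 3 (1.20 log units; beyond the scatter), a large step beyond the scatter. The estimate for compound 3 is 8000 nM, with a range from 2000 nM to 30000 nM.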

Compound 3, half-maximal cytotoxic concentration: 42000 nM
Compound 3: the middle estimate sits 5.3-fold (0.72 log units) below what was measured; measured number outside the range, above it.
By their numbers in this assay, from the lowest: compound 2; then compounds 1 and 3 (each within the scatter of the next).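

In this assay the swap of cyano for methoxy on the aromatic carbon ortho to a (3-methylbut-2-en-1-yl)oxy group and para to a (1,3-thiazol-2-yl)amino group gives an 84-fold higher number from compound 2 to compound 3 (1.92 log units; beyond the scatter) and so takes back the whole of the large step seen when cyano entered. Methoxy in place of hydrogen on that same carbon gives a 1.8-fold higher number from compound 1 to compound 3 (0.26 log units; within the scatter) and leaves compound 3 and compound 1 indistinguishable in this assay, so among hydrogen, methoxy and cyano at this position only cyano goes with the low number of compound 2. Nothing available here accounts for cyano standing apart from the other two groups.

Open, going by these compounds, is whether other groups on this carbon, such as fluorine, chlorine, a carboxamide or a carboxylic acid, stay with hydrogen and methoxy or move toward cyano. Also open, on these data alone, is whether the cyano step carries over when cyano sits on another carbon of the same ring, or when the (3-methylbut-2-en-1-yl)oxy group gives way to a shorter chain such as ethoxy.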